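The compounds below may be only part of what the source reports. "The series", "measured", "known", "first", "only" and "open" are said of these compounds alone.

Measured in an ADME assay on a cell-free system (plasma, Homo sapiens); a higher number here means a larger unbound share of the compound, a lower number a smaller unbound share:
- compound 1 `COc1c([C@H](C)Nc2ncnc3[nH]cnc23)cc(Cl)c(C)c1-c1ccc(S(C)(=O)=O)cc1`: 0.013
- compound 2 `COc1c([C@H](C)Nc2ncnc(N)c2C#N)cc(Cl)c(C)c1-c1ccc(C(=O)N(C)C)cn1`: 0.22
- compound 3 `COc1c([C@H](C)Nc2ncnc3[nH]cnc23)cc(Cl)c(C)c1-c1cncc(S(C)(=O)=O)c1`: 0.12

Compound 3, at 0.12, lies within the usual scatter of compound 2, while a 9.2-fold higher number from compound 1 to compound 3 (0.97 log units; beyond the scatter) marks a clear gap on the other side. Compound 4 `COc1c([C@H](C)Nc2ncnc(N)c2C#N)cc(Cl)c(C)c1-c1cncc(S(C)(=O)=O)c1` changes one group of compound 3: a group of 9 heavy atoms (5 carbon, 4 nitrogen; one six-membered aromatic ring with 2 hetero atoms) in place of a group of 9 heavy atoms (5 carbon, 4 nitrogen; one five-membered aromatic ring with 2 hetero atoms, one six-membered aromatic ring with 2 hetero atoms), on an amine nitrogen. Among the compounds with values here, no measured step covers this swap, and the only step available concerns a different place in the molecule. The best guide is compound 2 (0.22), which carries the same 6-amino-5-cyanopyrimidin-4-yl group but differs elsewhere. The expected step is small, a 1.3-fold higher number from compound 3 to compound 4 (0.12 log units; within the scatter), and is not expected to exceed the scatter. Compound 4 is estimated at 0.16, with an expected range of 0.08 to 0.32.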

Compound 4, unbound fraction: 0.14
Compound 4: middle estimate off by 1.1-fold (0.06 log units), on the high side, and the stated range covers the measured number.
By their numbers in this assay, from the lowest: compound 1; then compounds 3, 4 and 2 (each within the scatter of the next).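

On the amine nitrogen, 6-amino-5-cyanopyrimidin-4-yl can replace the two-ring group of compound 3 with only a 1.2-fold higher number from compound 3 to compound 4 (0.07 log units; within the scatter) in this assay. With that group kept, 5-(methylsulfonyl)pyridin-3-yl in place of 5-(dimethylcarbamoyl)pyridin-2-yl on the aromatic carbon gives a 1.6-fold lower number from compound 2 to compound 4 (0.20 log units; within the scatter), so neither single change separates these compounds. Nothing available explains either result.

Going by these compounds, it remains open whether 4-(methylsulfonyl)phenyl would give as low a number alongside 6-amino-5-cyanopyrimidin-4-yl as it does in compound 1. On these data alone, the effect of a carboxylic acid or an amine in place of methylsulfonyl also remains unknown.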